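This account rests on a few compounds, and the source may have more. Where it says the series, first, only, none or still open, it means among the compounds named here.

Three compounds built on one shared core have so far been run in a functional assay on MDA-MB-231 cells (Homo sapiens) for inhibition; on this read-out higher numbers stand for weaker inhibition and lower numbers for stronger inhibition. Compound 1 `O=C1C=CC(OCC(F)(F)F)N1c1cc(Cl)cc(Cl)c1` gives 2430 nM. Compound 2 `CC(C)c1ccc(N2C(=O)C=CC2OCC(F)(F)F)cc1` gives 6640 nM, and compound 3 `O=C1C=CC(OCC(F)(F)F)N1c1cc(F)cc(F)c1` gives 7840 nM. Among these three numbers compound 2 stands second highest; its nearest neighbour is compound 3, whose number differs from it by less than the usual scatter, while compound 1 lies furthest away with a lower number, a gap that exceeds the scatter.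

Compound 4 `O=C1C=CC(OCC(F)(F)F)N1c1ccc([N+](=O)[O-])cc1` has not yet been measured. It differs from compound 2 in one place: nitro in place of isopropyl on an aromatic carbon, on an aromatic carbon of a six-membered aromatic ring of carbon only, para to a large group. Going by the values given here, no pair of measured compounds shows this same change, so the data give no direct step to lean on. The step of a 1.5-fold lower number from compound 2 to compound 4 (0.17 log units; within the scatter) is expected to stay within the scatter. Compound 4 is therefore estimated at 4500 nM, within a range from 1500 nM to 14000 nM.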

Compound 4, half-maximal inhibitory concentration: 2830 nM
For compound 4 the middle estimate is 1.6-fold (0.20 log units) above the measured one; low and high end bracket the measured number.
By their numbers in this assay, from the lowest: compounds 1 and 4 (each within the scatter of the next); then compounds 2 and 3 (each within the scatter of the next).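

In this assay, going by these compounds alone, nitro in place of isopropyl on an aromatic carbon, para to a large group, gives a 2.3-fold lower number from compound 2 to compound 4 (0.37 log units; beyond the scatter), a modest step and the first reading of a change in one place, which the earlier compounds, with no such pair among them, could not provide. It shows that the number responds to the group held at this position, even though both groups count 3 heavy atoms; nitro counts 2 hydrogen-bond acceptors and isopropyl 0. Nothing available explains the step, so which difference between the two groups matters remains unknown.

This single pair leaves open whether the same change would give a similar step on a ring carrying other groups. It also leaves open where an amine, a carboxylic acid or a nitrile at this position would fall in this assay.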